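Aryl Replacement on the Core: Compound 3 to Compound 4

This account rests on a few compounds, and the source may have more. Where it says the series, first, only, none or still open, it means among the compounds named here.

Compound 3 `O=C(O)Cc1sc(C(c2ccc(F)cc2)c2ccc(F)cc2)nc1-c1cc(F)cc(F)c1` stands in an in vitro functional assay on HEK285-7 cells for antagonist activity at prostaglandin D2 receptor 2 (Homo sapiens), read by BRET and beta-arrestin recruitment (on this read-out higher numbers stand for larger maximal responses and lower numbers for smaller maximal responses), at 80%, level with compound 2 `O=C(O)Cc1sc(C(c2ccc(F)cc2)c2ccc(F)cc2)nc1-c1ccnc(Cl)c1`, which gives 80%; together these are the highest of the three numbers. Compound 1 `COc1cc(-c2nc(C(c3ccc(F)cc3)c3ccc(F)cc3)sc2CC(=O)O)ccn1` gives 60%, the lowest of the three. The step of a number 20 percentage points higher from compound 1 to compound 3 (beyond the scatter) and the step of no change at the digits printed from compound 2 to compound 3 (within the scatter) both exchange the same aromatic substituent that changes on going to compound 4 `O=C(O)Cc1sc(C(c2ccc(F)cc2)c2ccc(F)cc2)nc1-c1ccoc1`, where (furan-3-yl in place of 3,5-difluorophenyl on an aromatic carbon). One of these steps was a modest rise, the other no change, so this position tolerates exchange of the aryl group. Neither step covers a five-membered ring with one hetero atom; a step within the scatter is expected here. Compound 4 is therefore estimated at 72%, between 55% and 90%, with the expected step of a number 8 percentage points lower from compound 3 to compound 4 (within the scatter).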

Compound 4, largest response reached (reported as efficacy), in percent of the reference or control that the assay uses: 80%
For compound 4 the middle estimate is 8 percentage points below the measured one, and the stated range covers the measured number.
By their numbers in this assay, from the lowest: compound 1; then compounds 2, 3 and 4 (each within the scatter of the next).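

In this assay, a five-membered aromatic ring with 1 hetero atom on this aromatic carbon, at 5 heavy atoms instead of 8, gives no change at the digits printed from compound 3 to compound 4 (within the scatter), and no change at the digits printed from compound 2 to compound 4 (within the scatter). Against the 2-methoxypyridin-4-yl group, furan-3-yl gives a number 20 percentage points higher from compound 1 to compound 4 (beyond the scatter), leaving compound 1 as the only compound apart from the others. Nothing available explains these steps.

Open, from the compounds shown here alone, is whether a non-aromatic group at this place, such as an amine or a longer alkyl chain, gives a similar response. Going by these compounds, the effect of a methoxy group on the furan ring also remains open.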